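Pyrimidin-2-yl in place of phenyl: working notes

This account rests on a few compounds, and the source may have more. Where it says the series, first, only, none or still open, it means among the compounds named here.

Compound 1 `C[C@H](NC(=O)CC(F)(F)F)c1ccc(NC(=O)[C@H]2C[C@@H]2c2cccnc2)cc1` gives 5 nM
Compound 2 `C[C@H](NC(=O)[C@@H]1CCCN1C)c1ccc(NC(=O)[C@H]2C[C@@H]2c2cccnc2)cc1` gives 1 nM
Compound 3 `C[C@H](NC(=O)c1ccccc1)c1ccc(NC(=O)[C@H]2C[C@@H]2c2cccnc2)cc1` gives 1 nM

In a functional assay on A2780 cells (Homo sapiens) for antiproliferative activity, read by CellTiter-Glo, with a stated time of 4 days (on this read-out higher numbers stand for weaker inhibition and lower numbers for stronger inhibition), compound 2 and compound 3 stand level at 1 nM, together the lowest of the three numbers. Compound 1 lies apart, with a 5.0-fold lower number from compound 1 to compound 3 (0.70 log units; beyond the scatter).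

Compound 4 `C[C@H](NC(=O)c1ncccn1)c1ccc(NC(=O)[C@H]2C[C@@H]2c2cccnc2)cc1` carries pyrimidin-2-yl in place of phenyl on a carbonyl carbon.

All three measured steps fall at this same place. Two are modest, a 5.0-fold lower number from compound 1 to compound 2 (0.70 log units; beyond the scatter) and a 5.0-fold lower number from compound 1 to compound 3 (0.70 log units; beyond the scatter), and both leave 2,2,2-trifluoroethyl. The third is no change at the digits printed from compound 2 to compound 3 (within the scatter), so two quite different groups give the same number. Among the compounds with values here, no measured compound has an aromatic ring with hetero atoms at this place, which leaves the direction open.

A step no larger than the modest ones is expected, leaning slightly towards a higher number: a 2.0-fold higher number from compound 3 to compound 4 (0.30 log units; within the scatter). The estimate for compound 4 is 2 nM, with an expected range from 0.6 nM to 6 nM.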

Compound 4, half-maximal inhibitory concentration: 14 nM
Compound 4: the middle estimate sits 7.0-fold (0.85 log units) below what was measured; measured number above the stated range.
By their numbers in this assay, from the lowest: compounds 2 and 3 (each within the scatter of the next); then compound 1; then compound 4.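

In this assay, this place on a carbonyl carbon first shows a large step when phenyl gives way to pyrimidin-2-yl (a 14-fold higher number from compound 3 to compound 4 (1.15 log units; beyond the scatter)), and the step from the 1-methylpyrrolidin-2-yl amide is of the same size (a 14-fold higher number from compound 2 to compound 4 (1.15 log units; beyond the scatter)). The new ring also falls behind 2,2,2-trifluoroethyl, until now the group with the highest number (a 2.8-fold higher number from compound 1 to compound 4 (0.45 log units; beyond the scatter)), so the place that gave similar numbers for phenyl and 1-methylpyrrolidin-2-yl does separate two six-membered aromatic rings with the same count of heavy atoms. Nothing available accounts for this loss.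

Open, from the compounds shown here alone, is whether pyridin-2-yl, with one ring nitrogen, at this place falls with phenyl or with pyrimidin-2-yl. Pyrimidin-5-yl would show whether the step follows the ring nitrogens as such or their arrangement around the bond to the carbonyl.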